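Furan to oxazole amide: toxicity outlook for compound 4

The compounds below may be only part of what the source reports. "The series", "measured", "known", "first", "only" and "open" are said of these compounds alone.

Compound 1 `COc1ccccc1-c1cnc(NC(=O)c2ccc(F)cc2)n1C` gives > 100000 nM in a toxicity assay on THP-1 cells (Homo sapiens) for inhibition; on this read-out higher numbers stand for lower toxicity in this test and lower numbers for higher toxicity in this test.
Compound 2 `Cn1c(-c2cccc(C#N)c2)cnc1NC(=O)c1ccc(F)cc1` gives > 100000 nM in this assay.
Compound 3 `COc1ccc(-c2cnc(NC(=O)c3ccco3)n2C)cc1` gives > 100000 nM in this assay.

Each of these three values is a limit of the assay rather than a measured number, as summed up in the limit of > 100000 nM in this assay, at which 3 of the 3 values shown sit. Compound 3 therefore stands at that limit, and the two other values shown sit at the same limit, so nothing separates compound 3 from them on the numbers known. For the measured compounds named here, the one step between measured compounds that differ in a single place, a step that the two limits leave unreadable from compound 1 to compound 2, concerns a different part of the molecule and has no readable size, so it offers no guidance on the change considered here.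

Compound 4 `COc1ccc(-c2cnc(NC(=O)c3cnco3)n2C)cc1` differs from compound 3 in one place: 1,3-oxazol-5-yl in place of furan-2-yl on a carbonyl carbon. Going by the values given here, no measured step bears on this change, and every value sits at the limit. The step that the limit leaves unreadable from compound 3 to compound 4 is therefore expected to be none beyond the scatter. Compound 4 is expected to give about 150000 nM in this assay, within a range from 60000 nM to 400000 nM, and most likely the assay will again report only a limit.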

Compound 4, half-maximal cytotoxic concentration: > 100000 nM
Compound 4: only a limit was reported (the forecaster's own chance of this, stated with the estimate: 80%); the middle value is on the limit's open side.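

Compound 3 and compound 4 both give only a limit in this assay, not a measured number, so no size can be read for 1,3-oxazol-5-yl in place of furan-2-yl. The compounds shown leave open whether their toxicity differs at all, and which change would bring a value into the readable range: the limit of > 100000 nM in this assay, at which 4 of the 4 values shown sit.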